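Fluoro in Place of Hydrogen on Aryl Sulfonamides

The source may report more compounds than this note shows. Statements on the series, on what has been measured and on what is new or still open speak of the compounds shown alone.

Compound 1, `O=S(=O)(Nc1ccccc1)c1ccc(Br)cc1`, gives 8.5 in a physicochemical assay for acid dissociation.
Compound 2, `O=S(=O)(Nc1ccc(F)cc1)c1ccc(Br)cc1`, gives 8.38 in this assay.
Compound 3, `Cc1ccc(NS(=O)(=O)c2ccccc2)cc1`, gives 9.34 in this assay.

Compound 1 and compound 2 differ by one change, (fluoro in place of hydrogen on an aromatic carbon), and the step in this assay is a number 0.12 log units lower from compound 1 to compound 2 (within the scatter). Compound 3 gives a higher number than compound 1 and compound 2; how the core of compound 3 differs from the core of compound 1 is not broken down here.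

Compound 4, `Cc1ccc(NS(=O)(=O)c2ccc(F)cc2)cc1`, is not yet measured. It differs from compound 3 by fluoro in place of hydrogen on an aromatic carbon, the same change that separates compound 1 from compound 2, at the same kind of place. Because the step of a number 0.12 log units lower from compound 1 to compound 2 (within the scatter) is small, the step from compound 3 to compound 4 is expected to be a number 0.12 log units lower from compound 3 to compound 4 (within the scatter). Compound 4 is therefore estimated at 9.22, likely between 8.9 and 9.5.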

Compound 4, acid dissociation constant: 9.23
The estimate for compound 4 lay 0.01 log units below the measured number; the range from low to high includes it.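

In this assay, fluoro in place of hydrogen on an aromatic carbon gives a number 0.11 log units lower from compound 3 to compound 4 (within the scatter), and the same change on the other core gave a number 0.12 log units lower from compound 1 to compound 2 (within the scatter). In these two cores, then, the change carries over as a step too small to tell apart from repeat scatter, but two pairs cannot show that it would stay this small on every core in the series. Nothing available here explains why the step is small.

Still open, from the compounds shown here alone, is what an amine or a carboxylic acid on that aromatic carbon would give. The compounds shown also leave open whether the fluoro step stays this small on further cores.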